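This account rests on a few compounds, and the source may have more. Where it says the series, first, only, none or still open, it means among the compounds named here.

The study concerns inhibition of myosin-2, followed in an assay on isolated protein for inhibition of myosin-2 (Bos taurus), read by spectrophotometry, with a stated time of 24 min; on this read-out lower numbers stand for stronger inhibition and higher numbers for weaker inhibition. Three measured compounds share one core. Compound 1 `C/C(=N\CCO)c1c(O)c2ccccc2[nH]c1=O` carries 2-hydroxyethyl on a double-bonded nitrogen. In this assay compound 1 gives >= 100000 nM, which is a limit of the assay and not a number. Compound 2 `CCC(C)/N=C(\C)c1c(O)c2ccccc2[nH]c1=O` has sec-butyl in place of 2-hydroxyethyl on that nitrogen. In this assay compound 2 gives >= 100000 nM, again a limit. The step that the two limits leave unreadable from compound 1 to compound 2 therefore has no readable size. Compound 3 `CCC(C)/N=C(\C)c1c(O)c2ccccc2oc1=O` keeps the sec-butyl on a changed core. In this assay compound 3 gives >= 100000 nM, likewise a limit. Every value shown sits at the limit of >= 100000 nM in this assay, at which 3 of the 3 values shown sit, so compound 3 stands with the others at the edge of what this assay can report, and the pair of compound 2 and compound 3 shows only two limits.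

Compound 4 `C/C(=N\Cc1cccnc1)c1c(O)c2ccccc2oc1=O` differs from compound 3 by (pyridin-3-yl)methyl in place of sec-butyl on a double-bonded nitrogen. Going by the values given here, no measured step bears on this change; the one step available, from compound 1 to compound 2, is unreadable between two limits. With nothing pointing toward stronger inhibition, the expected step in this assay is a number no higher from compound 3 to compound 4 (the limit leaves the size open), none beyond the scatter, and compound 4 is expected most likely to return a limit again. The estimate for compound 4 is 100000 nM, with a range from 30000 nM to 300000 nM.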

Compound 4, half-maximal inhibitory concentration: 17000 nM
Beside the measured number, compound 4's estimate is 5.9-fold (0.77 log units) above it; measured number outside the range, below it.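

In this assay, the group on the double-bonded nitrogen proves able to move the read-out: (pyridin-3-yl)methyl in place of sec-butyl gives an at least 5.8-fold lower number from compound 3 to compound 4 (0.76 log units; beyond the scatter). Going by these compounds alone, this is the first step that can be read, since the earlier steps lie between two limits and cannot be read, so it is the first sign that this position responds to a change of group, at least on the core of compound 3. Compound 1, compound 2 and compound 3 each remain at a limit of the assay, which is not a number: the limit of >= 100000 nM in this assay, at which 3 of the 4 values shown sit.

As far as these compounds go, what stays open is which part of the entering group goes with the step, the aromatic ring, its ring nitrogen or the length of the link, and how benzyl, pyridin-2-ylmethyl or the longer chain 2-(pyridin-3-yl)ethyl would stand at this position in this assay. From the compounds shown here alone, it also stays open whether (pyridin-3-yl)methyl would give a readable number on the core of compound 1, so the step cannot yet be taken as holding beyond the core of compound 3.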